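Moving a Fluorine Within the Outer Ring

The compounds below may be only part of what the source reports. "The series", "measured", "known", "first", "only" and "open" are said of these compounds alone.

Three compounds have been measured in an assay on isolated protein for inhibition of 2-Hydroxyacid oxidase 2 (Rattus norvegicus); on this read-out higher numbers stand for weaker inhibition and lower numbers for stronger inhibition:

Compound 1, `Cc1n[nH]c(C(=O)O)c1Cc1cccc(-c2cccc(F)c2)c1`, gives 500 nM.
Compound 2, `Cc1n[nH]c(C(=O)O)c1Cc1cccc(C(F)(F)F)c1`, gives 300 nM.
Compound 3, `Cc1n[nH]c(C(=O)O)c1Cc1cccc2ccccc12`, gives 200 nM.

Compound 1 stands highest of the three numbers in this assay, which means it is the weakest inhibitor shown. Its nearest neighbour is compound 2, reached by a 1.7-fold lower number from compound 1 to compound 2 (0.22 log units; within the scatter), a step that lies within the scatter. Compound 3 is furthest away, and its value lies beyond the scatter from that of compound 1, though no single change links the two.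

Compound 4, `Cc1n[nH]c(C(=O)O)c1Cc1cccc(-c2ccccc2F)c1`, has not yet been measured. It differs from compound 1 only in the outer ring: 2-fluorophenyl in place of 3-fluorophenyl on an aromatic carbon. For the measured compounds named here, no measured step moves a fluorine within that ring. The closest guide is a 1.7-fold lower number from compound 1 to compound 2 (0.22 log units; within the scatter), where the whole 3-fluorophenyl was exchanged for trifluoromethyl and the number hardly moved. Exchanging 3-fluorophenyl for 2-fluorophenyl is a smaller alteration than that, so no step beyond the scatter is expected in this assay.

Compound 4 is therefore expected at 500 nM, with a range from 250 nM to 1000 nM. The expected step is no change at the digits printed from compound 1 to compound 4 (within the scatter), staying within the scatter.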

Compound 4, half-maximal inhibitory concentration: 900 nM
Estimate against measurement, compound 4: 1.8-fold (0.26 log units) below; the range from low to high includes it.
By their numbers in this assay, from the lowest: compounds 3, 2, 1 and 4 (each within the scatter of the next, the first and the last beyond it).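

In this assay, shifting the fluorine from 3-fluorophenyl to 2-fluorophenyl gives a 1.8-fold higher number from compound 1 to compound 4 (0.26 log units; within the scatter) and so cannot be told apart from the ordinary spread of repeated measurements. For the compounds shown here, exchanging trifluoromethyl for 2-fluorophenyl at this place, however, gives a 3.0-fold higher number from compound 2 to compound 4 (0.48 log units; beyond the scatter) and is the first single change here to clear that spread. The group on this aromatic carbon can therefore shift the number, although compound 1 and compound 2 remain within the scatter of each other, so the two fluorophenyl groups are not separated by this result.

From the compounds shown here alone, whether an amine or a longer chain in place of the outer ring would give a stronger or weaker number stays open. Nothing available explains why these values differ.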